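The compounds below may be only part of what the source reports. "The series", "measured", "known", "first", "only" and "open" are said of these compounds alone.

Measured so far in a functional assay on HT-29 cells (Homo sapiens) for inhibition, read by sulforhodamine B assay, with a stated time of 72 h; on this read-out higher numbers stand for weaker inhibition and lower numbers for stronger inhibition:

Compound 1, `CCOc1ccc(C2C(C3CC3)C(=O)N2c2cc(OC)c(OC)c(OC)c2)cc1`: 63 nM
Compound 2, `CCSc1ccc(C2C(Oc3ccccc3)C(=O)N2c2cc(OC)c(OC)c(OC)c2)cc1`: 632 nM
Compound 3, `COc1ccc(C2C(Oc3ccccc3)C(=O)N2c2cc(OC)c(OC)c(OC)c2)cc1`: 52 nM

Among these three, compound 2 stands highest, meaning it is the weakest inhibitor of the set. Compound 1 gives 63 nM, and compound 3 gives 52 nM, both well below compound 2.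

The unmeasured compound 4, `CCSc1ccc(C2C(C3CC3)C(=O)N2c2cc(OC)c(OC)c(OC)c2)cc1`, differs from compound 2 in one place: cyclopropyl in place of phenoxy on a saturated ring carbon.

For the measured compounds named here, only one single-change step is known in this assay, a 12-fold lower number from compound 2 to compound 3 (1.08 log units; beyond the scatter), and it concerns a change on an aromatic carbon, not the exchange on the saturated ring carbon considered here. Compound 1 carries the cyclopropyl and compound 3 carries the phenoxy, but the two also differ in ethoxy against methoxy, so they do not form a single step; their values lie close to one another, within the usual scatter. On that thin basis the swap of phenoxy for cyclopropyl is expected to leave the number roughly where it is, with the step from compound 2 to compound 4 expected to be a 1.3-fold lower number from compound 2 to compound 4 (0.10 log units; within the scatter). Compound 4 is therefore estimated at 500 nM, with a range from 150 nM to 1500 nM.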

Compound 4, half-maximal inhibitory concentration: 1560 nM
Compound 4: middle estimate off by 3.1-fold (0.49 log units), on the low side, and the stated range ends below it.
By their numbers in this assay, from the lowest: compounds 3 and 1 (each within the scatter of the next); then compound 2; then compound 4.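

In this assay, for the compounds shown here, this saturated ring carbon proves sensitive to what it carries: with the 4-(ethylsulfanyl)phenyl group kept in place, changing phenoxy (7 heavy atoms) to cyclopropyl (3 heavy atoms) gives a 2.5-fold higher number from compound 2 to compound 4 (0.39 log units; beyond the scatter) and so a weaker inhibitor, a modest loss but one that a newcomer to the series could not have read from the earlier compounds. The sulfur-for-oxygen side of the series also gains a second example, since a 25-fold higher number from compound 1 to compound 4 (1.39 log units; beyond the scatter) appears with cyclopropyl on the ring, and a 12-fold lower number from compound 2 to compound 3 (1.08 log units; beyond the scatter) had already shown the ethylsulfanyl compound with the higher number when phenoxy was there, so in both pairs the ethylsulfanyl compound is the weaker one. Nothing here measures why either change acts as it does, and no supporting data on that question are available.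

Whether phenoxy also beats cyclopropyl when ethoxy or methoxy sits on the aromatic ring stays open, as no pair shown tests that exchange with either group. Also open, as far as these compounds go, is how this ring carbon would respond to quite different groups, such as an amine, a hydroxyl or a longer chain like n-butyl.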